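The compounds below may be only part of what the source reports. "The series", "measured", "known", "first", "only" and "open" are said of these compounds alone.

Measured in a functional assay on MIA PaCa-2 cells (Homo sapiens) for inhibition, read by MTT assay, with a stated time of 72 h; a lower number here means a stronger inhibitor, a higher number a weaker inhibitor:
- Compound 1 `CCCCCCCC/C=C\CCCCCCCCOC[C@@H]1CCCN1C(=O)OC(C)(C)C`: > 100000 nM (a limit)
- Compound 2 `CCCCCCCC/C=C/CCCCCCCCOC[C@@H]1CCCN1C(=O)OC(C)(C)C`: > 100000 nM (a limit)
- Compound 3 `CCCCCCCC/C=C/CCCCCCCCOC[C@@H]1CCCN1`: 4200 nM

Compound 2 has no exact number, only a limit: the limit of > 100000 nM in this assay, at which 2 of the 3 values shown sit. Compound 4 `CC(C)(C)OC(=O)N1CCC[C@H]1COCCCCCCCC/C=C/c1ccc(-c2ccccc2)cc1` differs from compound 2 by 4-phenylphenyl in place of octyl on a double-bonded chain carbon bound to a double-bonded chain carbon. This places 4-phenylphenyl in place of octyl on a double-bonded chain carbon bound to a double-bonded chain carbon.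

Among the compounds with values here, no measured step makes this exchange, so the evidence is indirect. The step that the two limits leave unreadable from compound 1 to compound 2 says little, given (the fact that compounds 1 and 2 differ only in the configuration as drawn). The other step, an at least 23-fold lower number from compound 2 to compound 3 (1.37 log units; beyond the scatter), is a change on the ring nitrogen. Compound 4 keeps the tert-butoxycarbonyl group found on compound 2, so that large gain is not expected to carry over. No clear step in either direction is therefore expected in this assay, and a further limit is the likeliest result.

The expected outcome is an at least 1.2-fold lower number from compound 2 to compound 4 (0.09 log units; that floor lies within the scatter). For compound 4, the estimate is 80000 nM, with an expected range of 25000 nM to 150000 nM.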

Compound 4, half-maximal inhibitory concentration: 69200 nM
For compound 4 the middle estimate is 1.2-fold (0.06 log units) above the measured one; the range from low to high includes it.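

In this assay compound 4 gives 69200 nM, the only exact number among the compounds shown that keep tert-butoxycarbonyl on the amine nitrogen in the ring. Compound 2 has only a limit, > 100000 nM. Exchanging octyl for 4-phenylphenyl on this double-bonded chain carbon is read as an at least 1.4-fold lower number from compound 2 to compound 4 (0.15 log units; that floor lies within the scatter), so the change shows no clear gain, and its true size stays unknown because of where compound 2 stands: the limit of > 100000 nM in this assay, at which 2 of the 4 values shown sit.

On these data alone, it remains open whether a plain phenyl group or a longer chain at this position would give a different result. As far as these compounds go, it is also open whether 4-phenylphenyl would give a different result with hydrogen in place of tert-butoxycarbonyl on the ring nitrogen.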